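A few compounds are considered here, and "the series" means these few. Any claim that something is new, unique, unknown or untested is made for them only; others in the source may bear on it.

Measured so far:
- compound 1 `Cc1noc(C)c1CN(C1Cc2cc(C#N)ccc2N(Cc2cncn2C)C1)S(=O)(=O)c1ccccn1`: 8 10^-6 cm/s
- compound 2 `Cn1cncc1CN1CC(N(CC2CCN(C(=O)N3CCCC3)CC2)S(=O)(=O)c2ccccn2)Cc2cc(C#N)ccc21`: 0.6 10^-6 cm/s
- compound 3 `Cn1cncc1CN1CC(N(CC2CCN(C(=O)C3CCCC3)CC2)S(=O)(=O)c2ccccn2)Cc2cc(C#N)ccc21`: 0.5 10^-6 cm/s

In an ADME assay on Caco-2 cells (Homo sapiens) for permeability, in the apical to basolateral direction (on this read-out higher numbers stand for higher permeability and lower numbers for lower permeability), compound 3 sits at the low end of the three numbers; compound 2 lies within the scatter of it, while compound 1 stands beyond the scatter above both. Among the compounds with values here, the only step between neighbours, a 1.2-fold lower number from compound 2 to compound 3 (0.08 log units; within the scatter), is within the scatter.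

Compound 4 `CC(C)S(=O)(=O)N1CCC(CN(C2Cc3cc(C#N)ccc3N(Cc3cncn3C)C2)S(=O)(=O)c2ccccn2)CC1` differs from compound 3 by isopropylsulfonyl in place of cyclopentylcarbonyl on an amine nitrogen in a ring. Within the data shown here, no measured step covers a sulfonyl entering at this nitrogen; the one step that bears on this position, a 1.2-fold lower number from compound 2 to compound 3 (0.08 log units; within the scatter), was within the scatter, so no step beyond the scatter is expected here either: no change at the digits printed from compound 3 to compound 4 (within the scatter). Compound 4 is therefore estimated at 0.5 10^-6 cm/s, with a range from 0.2 10^-6 cm/s to 1.3 10^-6 cm/s.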

Compound 4, apparent permeability: 0.1 10^-6 cm/s
Estimate against measurement, compound 4: 5.0-fold (0.70 log units) above, and the stated range ends above it.
By their numbers in this assay, from the lowest: compound 4; then compounds 3 and 2 (each within the scatter of the next); then compound 1.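

In this assay the group on the amine nitrogen in a ring now separates compounds: isopropylsulfonyl in place of a carbonyl-linked group gives a 5.0-fold lower number from compound 3 to compound 4 (0.70 log units; beyond the scatter) and also a 6.0-fold lower number from compound 2 to compound 4 (0.78 log units; beyond the scatter), whereas the exchange between the two carbonyl-linked groups stayed within the scatter. With the whole 1-(isopropylsulfonyl)piperidin-4-yl in place of 3,5-dimethyl-1,2-oxazol-4-yl, the series shows an 80-fold lower number from compound 1 to compound 4 (1.90 log units; beyond the scatter). No measurement shown explains the sulfonyl result. On these data alone, whether a smaller methylsulfonyl or a free ring amine at this nitrogen would follow compound 4 remains open.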